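This account rests on a few compounds, and the source may have more. Where it says the series, first, only, none or still open, it means among the compounds named here.

Compound 1 `COc1ccc(OC)c(N2C(=O)CSC2c2cccc(C(=O)NCCCCc3ccccc3)c2)c1` gives 1% in a functional assay on U2OS cells (Homo sapiens) for inhibition, read by CCK-8 assay, with a stated time of 72 h, tested at 1 uM (on this read-out lower numbers stand for less inhibition and higher numbers for more inhibition at the one concentration tested (going by the name of the read-out)), the lowest of the three measured numbers. Compound 2 `Cc1cccc(N2C(=O)CSC2c2cccc(C(=O)NCCCCc3ccccc3)c2)c1` gives 39% and compound 3 `O=C(NCCCCc1ccccc1)c1cccc(C2SCC(=O)N2c2ccccc2F)c1` gives 38% in this assay. The steps of a number 38 percentage points higher from compound 1 to compound 2 (beyond the scatter) and a number 37 percentage points higher from compound 1 to compound 3 (beyond the scatter) are both large, while a number 1 percentage points lower from compound 2 to compound 3 (within the scatter) stays within the scatter. Compound 4 `COc1ccc(N2C(=O)CSC2c2cccc(C(=O)NCCCCc3ccccc3)c2)c(OC)c1` differs from compound 1 by 2,4-dimethoxyphenyl in place of 2,5-dimethoxyphenyl on an amide-type nitrogen in a ring. Neither measured step exchanges one dimethoxyphenyl for another; both replaced it with a group carrying no methoxy. They bear on the new step only loosely, and a rise smaller than either is expected. The estimate for compound 4 in this assay is 15%, with a range from 0% to 35%, meaning an expected step of a number 14 percentage points higher from compound 1 to compound 4 (beyond the scatter).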

Compound 4, a percentage reported as inhibition, at one concentration (the size of the read-out at that concentration, not a potency): 37%
Estimate against measurement, compound 4: 22 percentage points below, outside the stated range (above it).
By their numbers in this assay, from the lowest: compound 1; then compounds 4, 3 and 2 (each within the scatter of the next).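

Relocating one methoxy group on the aryl ring, with the atoms unchanged, gives a number 36 percentage points higher from compound 1 to compound 4 (beyond the scatter) in this assay. Among these four compounds, the low number therefore goes with 2,5-dimethoxyphenyl and not with two methoxy groups as such, while a number 1 percentage points lower from compound 3 to compound 4 (within the scatter) and a number 2 percentage points lower from compound 2 to compound 4 (within the scatter) leave 2,4-dimethoxyphenyl level with the groups carrying no methoxy. No available evidence explains the difference between the two dimethoxy arrangements. As far as these compounds go, it remains open whether a single methoxy group, or a carboxylic acid or an amine on this phenyl ring, would fit the same picture.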